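From Pyridin-3-yl to Pyridin-2-yl on a Shared Core

A few compounds are considered here, and "the series" means these few. Any claim that something is new, unique, unknown or untested is made for them only; others in the source may bear on it.

Measured so far:
compound 1 `Cc1sc2c(Nc3cccnc3)cccc2c1C`: 76.1%
compound 2 `COc1cccc(Nc2cccc3c(C)c(C)sc23)c1`: 82.6%

In a functional assay for inhibition, with a stated time of 2 h, tested at 0.125 g/L (a lower number here means less inhibition, a higher number more inhibition at the concentration tested (going by the name of the read-out)), compound 1 stands lowest of the two numbers, but compound 2 lies within the usual scatter of it, so the two cannot be told apart. Compound 3 `Cc1sc2c(Nc3ccccn3)cccc2c1C` is not yet measured. It has the same atoms as compound 1, joined differently: pyridin-2-yl in place of pyridin-3-yl on a nitrogen on an aromatic ring. For the measured compounds named here, no step between measured compounds is known, so nothing shows whether such a change matters; no step beyond the scatter is expected in this assay. Compound 3 is estimated at 71%, between 50% and 88%. That estimate means an expected step of a number 5.1 percentage points lower from compound 1 to compound 3 (within the scatter), within the scatter.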

Compound 3, a percentage reported as inhibition, at one concentration (the size of the read-out at that concentration, not a potency): 45.9%
Compound 3: the middle estimate sits 25.1 percentage points above what was measured; the whole stated range lies above it.
By their numbers in this assay, from the lowest: compound 3; then compounds 1 and 2 (each within the scatter of the next).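

In this assay, pyridin-2-yl in place of pyridin-3-yl on a nitrogen on an aromatic ring gives a number 30.2 percentage points lower from compound 1 to compound 3 (beyond the scatter). This shows that the position is sensitive: two groups with the same atoms, joined differently, are not interchangeable on the shared core. Nothing available explains why the change has such an effect.

Still open, as far as these compounds go, is how a pyridin-4-yl or an unsubstituted phenyl group at this place would read in this assay. From the compounds shown here alone, whether the same swap on a different core gives a step of similar size also remains unknown.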